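A Fluoropyridyl Replaces a tert-Butylphenyl: Expected Potency

The source may hold more compounds than are shown below. What is called first, only, known or untested is meant among the compounds shown, and "the series" means these compounds.

The measured compounds, all tested in a functional assay on KYSE-410 cells (Homo sapiens) for antiproliferative activity, read by MTT assay, with a stated time of 72 h; a higher number here means a weaker inhibitor, a lower number a stronger inhibitor:
Compound 1, `O=C(Nc1ccc(F)cc1)c1ccnc2cc(Br)ccc12`, gives > 20000 nM, which is a limit of the assay rather than a number.
Compound 2, `O=C(Nc1cc(F)cc(F)c1)c1cc(=O)[nH]c2cc(O)ccc12`, gives > 20000 nM, again a limit of the assay.
Compound 3, `CC(C)(C)c1ccc(-c2ccc3c(C(=O)Nc4cccc(F)c4)cc(=O)[nH]c3c2)cc1`, gives > 20000 nM, also a limit of the assay.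

None of the three compounds yielded a measurable number; all sit at the same limit, as the evidence summarises: the limit of > 20000 nM in this assay, at which 3 of the 3 values shown sit. Compound 3 therefore cannot be ranked against compound 1 or compound 2; its only known position is at that limit, where the other two also stand.

Compound 4, `O=C(Nc1cccc(F)c1)c1cc(=O)[nH]c2cc(-c3cccnc3F)ccc12`, is the next compound to be measured. It differs from compound 3 in one place: 2-fluoropyridin-3-yl in place of 4-(tert-butyl)phenyl on an aromatic carbon. Among the compounds with values here, no step between measured compounds exists, so there is nothing to calibrate the size of this change against.

Within the data shown here, with every compound so far at the limit, the expectation for this assay is a step of no clear size in either direction, and most likely none beyond the scatter. Compound 4 is estimated at 15000 nM, in the range 3000 nM to 40000 nM, which would mean an expected step of an at least 1.3-fold lower number from compound 3 to compound 4 (0.12 log units; that floor lies within the scatter), with the likeliest outcome being that the assay again reports only a limit.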

Compound 4, half-maximal inhibitory concentration: 11600 nM
The estimate for compound 4 lay 1.3-fold (0.11 log units) above the measured number; the measured number falls inside the stated range.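

Within the data shown here, compound 4 is the first compound here to give a true number rather than a limit in this assay, which shows that a value can be read with a 2-fluoropyridin-3-yl at this position on the shared core. Putting that group in place of the 4-(tert-butyl)phenyl, which swaps a carbon-only ring for one holding a hetero atom and brings fewer heavy atoms, goes with an at least 1.7-fold lower number from compound 3 to compound 4 (0.23 log units; that floor lies within the scatter); the true step may be larger, but the part that can be stated does not clear the usual scatter, so this is a hint of a gain rather than a proven one. The series as a whole still stays close to the edge of what the assay can read: the limit of > 20000 nM in this assay, at which 3 of the 4 values shown sit.

On these data alone, whether the ring nitrogen, the fluorine or the loss of the tert-butyl group matters most remains open, as these changes arrive together in a single step. Also open, as far as these compounds go, is how this position would respond to a plain phenyl, an amine or a carboxylic acid, and whether any such group could bring the number well clear of the limit.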